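Shortening the alkyl chain on the shared core

This account rests on a few compounds, and the source may have more. Where it says the series, first, only, none or still open, it means among the compounds named here.

Measured so far:
compound 1, `C=CCn1c(=O)n(CCCCCCCC)c2nc(N)nc(O)c21`: 130%
compound 2, `C=CCn1c(=O)n(CCC(CCOCc2ccccc2)CCOCc2ccccc2)c2nc(N)nc(O)c21`: 68%

Both compounds share one core and differ in the chain carried on the ring nitrogen. In a functional assay on the whole organism (B cells) with Mus musculus as the target (on this read-out lower numbers stand for smaller maximal responses and higher numbers for larger maximal responses), compound 1 gives 130%, the higher of the two numbers. Compound 2, with its branched chain carrying two benzyloxy ends, gives 68% in this assay, and the gap to compound 1 lies beyond the scatter. Among the measured compounds shown here, no pair differing in only one place has been measured, so no step size is known from the data.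

Compound 3, `C=CCn1c(=O)n(CCCC)c2nc(N)nc(O)c21`, keeps the core and the allyl group and carries a butyl chain in place of the octyl chain of compound 1. The change from compound 1 to compound 3 reads (hydrogen in place of butyl on a saturated chain carbon, four bonds along the chain from an aromatic nitrogen). With nothing measured on chain length alone, the direction of the step is open; the expectation is a moderate fall, since compound 2 with its different chain gives 68% while compound 1 gives 130%. The step from compound 1 to compound 3 is expected to be a number 35 percentage points lower from compound 1 to compound 3 (beyond the scatter) in this assay. For compound 3 the estimate in this assay is 95%, with a range from 55% to 135%.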

Compound 3, largest response reached (reported as maximal response), in percent of the reference or control that the assay uses: 77%
Compound 3: the middle estimate sits 18 percentage points above what was measured; the measured number falls inside the stated range.
By their numbers in this assay, from the lowest: compounds 2 and 3 (each within the scatter of the next); then compound 1.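

In this assay the read-out now has its first step on chain length alone, with the shared core and the allyl group unchanged: a number 53 percentage points lower from compound 1 to compound 3 (beyond the scatter) for hydrogen in place of butyl on a saturated chain carbon, four bonds along the chain from an aromatic nitrogen. The outer part of the octyl chain of compound 1 therefore matters to the maximal response, and this position is sensitive to the change, which the earlier pair, differing in more than chain length, could not show. Nothing at hand gives a reason for the size of this step.

From the compounds shown here alone, two chain lengths give only two points, so the shape of the dependence stays open: a hexyl chain would show whether the response falls gradually between butyl and octyl or drops sharply at one length, and a decyl chain would show whether it continues to rise past octyl or turns down. Also open, going by these compounds, is whether a terminal amine or a carboxylic acid at the end of the octyl chain keeps the response of compound 1 or loses it.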